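The source may report more compounds than this note shows. Statements on the series, on what has been measured and on what is new or still open speak of the compounds shown alone.

Among the measured compounds shown here, compound 1 `COc1cc(C(=O)c2sc(-c3ccc(I)cc3)cc2N)cc(OC)c1OC` sits at the top of the three numbers measured so far: in a functional assay on CCRF-CEM cells (Homo sapiens) for antiproliferative activity (a lower number here means a stronger inhibitor, a higher number a weaker inhibitor), compound 1 gives 150 nM. Compound 2 `COc1cc(C(=O)c2sc(-c3ccncc3)cc2N)cc(OC)c1OC` gives 110 nM in this assay, and the step of a 1.4-fold lower number from compound 1 to compound 2 (0.13 log units; within the scatter) is too small to read as a change. Compound 3 `COc1cccc(-c2cc(N)c(C(=O)c3cc(OC)c(OC)c(OC)c3)s2)c1` gives 16 nM, a clear gap from compound 1 of a 9.4-fold lower number from compound 1 to compound 3 (0.97 log units; beyond the scatter) and from compound 2 of a 6.9-fold lower number from compound 2 to compound 3 (0.84 log units; beyond the scatter).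

Compound 4 `COc1ccc(-c2cc(N)c(C(=O)c3cc(OC)c(OC)c(OC)c3)s2)cc1` differs from compound 1 in one place: methoxy in place of iodo on an aromatic carbon. For the measured compounds named here, no measured step swaps 4-iodophenyl for 4-methoxyphenyl directly. The step from compound 1 to compound 3, which put 3-methoxyphenyl in place of 4-iodophenyl, brings in the same methoxy group on a different name of ring substituent and gave a modest drop of a 9.4-fold lower number from compound 1 to compound 3 (0.97 log units; beyond the scatter); the swap to pyridin-4-yl in compound 2 gave nothing beyond the scatter. Compound 4 is therefore expected to land a little below compound 1, by an estimated 1.9-fold lower number from compound 1 to compound 4 (0.27 log units; within the scatter), with the outcome of compound 3 suggesting a lower number is more likely than a higher one. The estimate for compound 4 in this assay is 80 nM, expected to fall between 30 nM and 220 nM.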

Compound 4, half-maximal inhibitory concentration: 19 nM
The estimate for compound 4 lay 4.2-fold (0.62 log units) above the measured number; measured number outside the range, below it.
By their numbers in this assay, from the lowest: compounds 3 and 4 (each within the scatter of the next); then compounds 2 and 1 (each within the scatter of the next).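

In this assay the change of iodo to methoxy on this ring gives a 7.9-fold lower number from compound 1 to compound 4 (0.90 log units; beyond the scatter) and so shows what compound 3 could not: the gain does not depend on moving the group to another carbon of the ring, since it also appears with methoxy in the place the iodo held. The position of the methoxy makes no readable difference, with a 1.2-fold higher number from compound 3 to compound 4 (0.07 log units; within the scatter) within the scatter, and 4-methoxyphenyl stands clear of pyridin-4-yl as well, with a 5.8-fold lower number from compound 2 to compound 4 (0.76 log units; beyond the scatter) beyond the scatter, so the two methoxyphenyl compounds sit together and apart from compounds 1 and 2. Nothing available explains why methoxy and iodo part in this way.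

The change replaces one iodine with a carbon and an oxygen that adds a hydrogen-bond acceptor, and the compounds shown cannot say whether that oxygen matters, which a methyl, an ethyl, a hydroxy or an ethoxy on the same carbon would help to settle. They also leave open how a chloro or fluoro would compare with iodo there, and whether a dimethylamino or a carboxylic acid would be accepted on this ring.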